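A Methoxy Group Replaces Bromine in the Vero Series

The source may hold more compounds than are shown below. What is called first, only, known or untested is meant among the compounds shown, and "the series" means these compounds.

Compound 1 `C=CCOc1cc(OC)c(C(=O)/C=C/C=C/c2ccccc2)c(OCC=C)c1`: "not determined" (no result reported)
Compound 2 `C=CCOc1cc(OC)c(C(=O)/C=C/c2ccc(O)cc2)c(OCC=C)c1`: 76400 nM
Compound 3 `C=CCOc1cc(OC)c(C(=O)/C=C/c2ccccc2Br)c(OCC=C)c1`: 13900 nM

Among the measured compounds shown here, all three compounds were taken into an ADME assay on Vero cells (Chlorocebus sabaeus) for cytotoxicity, read by MTT assay (a higher number here means a weaker inhibitor, a lower number a stronger inhibitor), but only two returned a number. Of those two, compound 3 has the lower, at 13900 nM, while compound 1 offers no comparison.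

The next compound, compound 4 `C=CCOc1cc(OC)c(C(=O)/C=C/c2ccc(OC)cc2)c(OCC=C)c1`, has 4-methoxyphenyl in place of 2-bromophenyl on a double-bonded chain carbon bound to a double-bonded chain carbon. For the measured compounds named here, only one measured step bears on this change, a 5.5-fold lower number from compound 2 to compound 3 (0.74 log units; beyond the scatter). It brought in the same 2-bromophenyl that now leaves, replacing 4-hydroxyphenyl. Compound 4 does not restore that group exactly, so the measured step can serve only as a rough guide, and a single step shows no pattern.

Even so, the name of the entering group is closer to that of 4-hydroxyphenyl, so part of the measured step is expected to reverse in this assay. This expectation rests on compound 2 at 76400 nM, which suggests a higher number, with a smaller step than the measured one. The expected step is a 2.5-fold higher number from compound 3 to compound 4 (0.40 log units; beyond the scatter).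

For compound 4, the estimated value is 35000 nM, with an expected range from 12000 nM to 100000 nM.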

Compound 4, half-maximal inhibitory concentration: 99900 nM
Compound 4: the middle estimate sits 2.9-fold (0.46 log units) below what was measured; the measured number falls inside the stated range.
By their numbers in this assay, from the lowest: compound 3; then compounds 2 and 4 (each within the scatter of the next).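

In this assay, 4-methoxyphenyl in place of 2-bromophenyl on a double-bonded chain carbon bound to a double-bonded chain carbon gives a 7.2-fold higher number from compound 3 to compound 4 (0.86 log units; beyond the scatter), a step of about the same size as the earlier one, in the opposite direction, and not the partial return that a single step had left possible. Methyl in place of hydrogen on an oxygen on an aromatic ring gives a 1.3-fold higher number from compound 2 to compound 4 (0.12 log units; within the scatter), which lies within the scatter, so 4-hydroxyphenyl and 4-methoxyphenyl cannot be told apart here, and among the compounds with a number only the 2-bromophenyl of compound 3 stands apart. Nothing available accounts for this separation, so the result remains a description of the numbers alone.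

Compound 3 differs from compounds 2 and 4 both in the atom it carries on the ring and in where the name places it, so the role of bromine cannot be separated from that of its position, a question that 4-bromophenyl or 2-methoxyphenyl on the same chain would address. As far as these compounds go, whether an unsubstituted phenyl, or an amine or a carboxylic acid on the ring, would fall with compound 3 or with compounds 2 and 4 also remains open.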